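This account rests on a few compounds, and the source may have more. Where it says the series, first, only, none or still open, it means among the compounds named here.

Three compounds share one core and differ only in the group on a double-bonded ring carbon of the six-membered non-aromatic carbon ring. Compound 1 `O=C1C=C(Nc2ccccc2)C(=O)c2c1nc1n2[C@H]2OC[C@@H](O)[C@H]2OC1` carries phenyl on an amine nitrogen, compound 2 `O=C1C=C(NC2CCCC2)C(=O)c2c1nc1n2[C@H]2OC[C@@H](O)[C@H]2OC1` cyclopentyl on that nitrogen and compound 3 `O=C1C=C(Nc2ccc(Br)cc2)C(=O)c2c1nc1n2[C@H]2OC[C@@H](O)[C@H]2OC1` 4-bromophenyl there. For the measured compounds named here, in a functional assay on MCF7 cells (Homo sapiens) for inhibition, read by sulforhodamine B assay (a lower number here means a stronger inhibitor, a higher number a weaker inhibitor), compound 3 gives 2580 nM, the only definite number among the three. For compound 1 this assay reports only a limit, > 4000 nM. For compound 2 it also reports only a limit, > 16000 nM. The step from compound 1 to compound 2 cannot be sized because compound 2 sits at the limit of > 16000 nM in this assay, at which 1 of the 3 values shown sits. What can be read is an at least 6.2-fold lower number from compound 2 to compound 3 (0.79 log units; beyond the scatter), and an at least 1.5-fold lower number from compound 1 to compound 3 (0.19 log units; that floor lies within the scatter), which lies within the scatter.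

Compound 4 `O=C1C=C(N2CCC2)C(=O)c2c1nc1n2[C@H]2OC[C@@H](O)[C@H]2OC1` differs from compound 3 in one place: azetidin-1-yl in place of (4-bromophenyl)amino on a double-bonded ring carbon. Going by the values given here, the one readable step, from a saturated ring on the nitrogen to an aromatic one, went toward a lower number, so the reverse direction here, to a small saturated ring without the amine hydrogen, is expected to raise the number. Compound 4 is therefore estimated at 12000 nM, between 3000 nM and 50000 nM, an expected step of a 4.7-fold higher number from compound 3 to compound 4 (0.67 log units; beyond the scatter), quite possibly ending as a limit rather than a number.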

Compound 4, half-maximal inhibitory concentration: > 16000 nM
Compound 4: only a limit was reported; the forecaster's own chance of this, stated with the estimate: 60%; at least 1.3-fold (0.12 log units) between middle value and limit.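

At this double-bonded ring carbon, azetidin-1-yl in place of (4-bromophenyl)amino gives an at least 6.2-fold higher number from compound 3 to compound 4 (0.79 log units; beyond the scatter) in this assay, so this step can be sized even though compound 4 has only a limit. Unlike the earlier changes, which swapped one ring on an amine nitrogen that kept its hydrogen, this one joins the ring through the nitrogen itself, leaves no amine hydrogen and removes the aromatic ring and the bromine, and the bromine-bearing compound 3 remains the only one of the four with a definite number. The steps from compound 1 and compound 2 to compound 4 cannot be read because these compounds are reported only as limits: the limit of > 16000 nM in this assay, at which 2 of the 4 values shown sit.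

For the compounds shown here, the single step changes the amine hydrogen, the aromatic ring and the bromine together, so it does not show which of them accounts for the rise. A (4-bromophenyl)(methyl)amino group would keep the bromophenyl ring without the amine hydrogen, and an azetidin-3-ylamino group would keep the amine hydrogen with a four-membered ring, so the answer would depend on compounds beyond those shown here.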